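Losing One Chlorine: Compound 2 to Compound 3

A few compounds are considered here, and "the series" means these few. Any claim that something is new, unique, unknown or untested is made for them only; others in the source may bear on it.

compound 1, `O=C(Nc1cccc(-n2cc(-c3ccncc3)c(-c3cc(O)cc(Cl)c3)n2)c1)Nc1ccc(Cl)c(Cl)c1`: 5.31%
compound 2, `COc1cc(Cl)cc(-c2nn(-c3cccc(NC(=O)Nc4ccc(Cl)c(C(F)(F)F)c4)c3)cc2-c2ccncc2)c1`: 9.38%

In a functional assay on CAKI-1 cells (Homo sapiens) for inhibition, read by sulforhodamine B assay, with a stated time of 48 h, tested at 10 uM (a higher number here means a weaker effect of the compound at the concentration tested, a lower number a stronger effect), compound 1 gives 5.31% and compound 2 gives 9.38%. Compound 2 has the higher of the two numbers, but compound 1 lies within the scatter of it, so the two cannot be ordered. Compound 3, `COc1cc(Cl)cc(-c2nn(-c3cccc(NC(=O)Nc4cccc(C(F)(F)F)c4)c3)cc2-c2ccncc2)c1`, differs from compound 2 in one place: hydrogen in place of chloro on an aromatic carbon. Going by the values given here, no measured pair shows this change, so only a small step is expected in this assay, if anything toward a higher number and likely not beyond the scatter: a number 5.6 percentage points higher from compound 2 to compound 3 (within the scatter). Compound 3 is therefore expected to give about 15%, within a range from 4% to 35%.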

Compound 3, a percentage reported as activity, at one concentration (the size of the read-out at that concentration, not a potency): 16.1%
Compound 3: middle estimate off by 1.1 percentage points, on the low side; the range from low to high includes it.
By their numbers in this assay, from the lowest: compounds 1, 2 and 3 (each within the scatter of the next, the first and the last beyond it).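

Replacing chloro with hydrogen on the aromatic carbon ortho to the trifluoromethyl group turns 4-chloro-3-(trifluoromethyl)phenyl into 3-(trifluoromethyl)phenyl and gives in this assay a number 6.7 percentage points higher from compound 2 to compound 3 (within the scatter) for this one-atom change. At this carbon, then, the chloro group is not shown to matter for the read-out at the concentration tested, since compound 2 and compound 3 cannot be ordered. Nothing available explains the size of this step. From the compounds shown here alone, how a fluoro group, a methoxy group or an amine on this carbon would read remains open. So does whether the same change would give a similar step in other compounds.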